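Solubility across amine chain homologues of the shared core

A few compounds are considered here, and "the series" means these few. Any claim that something is new, unique, unknown or untested is made for them only; others in the source may bear on it.

Compound 3 `CCCCCNC1CC(=O)OC1C(O)C(=O)NC(CC(C)C)C1Cc2cccc(O)c2C(=O)O1` holds the higher of the two numbers in a physicochemical assay for solubility (a lower number here means a less soluble compound, a higher number a more soluble compound), giving 7300 ug/mL. Compound 2 `CNC1CC(=O)OC1C(O)C(=O)NC(CC(C)C)C1Cc2cccc(O)c2C(=O)O1` gives 1500 ug/mL in this assay. Compound 1 `CCCNC1CC(=O)OC1C(O)C(=O)NC(CC(C)C)C1Cc2cccc(O)c2C(=O)O1` sits at the limit of > 100000 ug/mL in this assay, at which 1 of the 3 values shown sits, reporting > 100000 ug/mL as a limit and not a number. Compound 4 `CCCCCCNC1CC(=O)OC1C(O)C(=O)NC(CC(C)C)C1Cc2cccc(O)c2C(=O)O1` differs from compound 3 by methyl in place of hydrogen on a saturated chain carbon, five bonds along the chain from an amine nitrogen. The measured steps that bear on it pull in opposite directions: a 4.9-fold higher number from compound 2 to compound 3 (0.69 log units; beyond the scatter), whereas an at least 13-fold lower number from compound 1 to compound 3 (1.13 log units; beyond the scatter), and an at least 66-fold lower number from compound 1 to compound 2 (1.82 log units; beyond the scatter). With the nearest step modest and upward but the longer-chain comparison downward, no step beyond the scatter is expected, a 1.5-fold lower number from compound 3 to compound 4 (0.16 log units; within the scatter). Compound 4 is therefore estimated at 5000 ug/mL, within a range from 1500 ug/mL to 16000 ug/mL.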

Compound 4, solubility: 1600 ug/mL
Compound 4: the middle estimate sits 3.1-fold (0.49 log units) above what was measured; low and high end bracket the measured number.
By their numbers in this assay, from the lowest: compounds 2 and 4 (each within the scatter of the next); then compound 3. At a limit, above all of these: compound 1.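

In this assay the added methyl, on a saturated chain carbon five bonds along the chain from the amine nitrogen, turns the series downward (a 4.6-fold lower number from compound 3 to compound 4 (0.66 log units; beyond the scatter)). Compound 2 and compound 4 stand level (a 1.1-fold higher number from compound 2 to compound 4 (0.03 log units; within the scatter)), so no steady trend with chain length holds across compounds 1 to 4. Compound 1 carries a limit and not a number, so the step to the longest chain shown is only bounded (an at least 62-fold lower number from compound 1 to compound 4 (1.79 log units; beyond the scatter)): the limit of > 100000 ug/mL in this assay, at which 1 of the 4 values shown sits.

Open, from the compounds shown here alone, is what a butyl chain on the amine, or a longer chain, gives in this assay, and whether a carboxylic acid at the chain end changes the picture.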